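The source may report more compounds than this note shows. Statements on the series, on what has been measured and on what is new or still open speak of the compounds shown alone.

Measured compounds:
compound 1 `COCCCNC(=O)COc1ccc2c(c1)c(CCc1ccccc1)c(-c1ccc(F)cc1F)c(=O)n2C` — an assay on CHO cells for displacement of a labelled ligand from adenosine receptor A2b (Homo sapiens), read by scintillation counting, with a stated time of 60 min; a higher number here means a weaker inhibitor, a lower number a stronger inhibitor: 677 nM
compound 2 `CC(C)(NC(=O)NCc1ccc2[nH]c(=O)c(-c3nccs3)c(CCc3ccccc3)c2c1)c1ccccc1` — this assay: "not determined" (no result reported)

Compound 2 stands outside the numbers: in this assay compound 2 has no reported value, so only compound 1 carries a figure. Compound 3 `O=C(CCc1ccccc1)NCc1ccc2[nH]c(=O)c(-c3nccs3)c(CCc3ccccc3)c2c1` arises from compound 2 by phenethyl in place of (1-methyl-1-phenylethyl)amino on a carbonyl carbon. With no number for compound 2, no size or direction of step in this assay can be given; the change is followed without a comparison figure. Resting on the single value of compound 1 677 nM, compound 3 is estimated at 600 nM, range 100 nM to 4000 nM.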

Compound 3, inhibition constant: 291 nM
Beside the measured number, compound 3's estimate is 2.1-fold (0.31 log units) above it; measured number inside the range.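

No step can be read from compound 2 to compound 3 in this assay. The compounds shown leave open what phenethyl in place of (1-methyl-1-phenylethyl)amino does to the read-out. No evidence bears on this result.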